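A few compounds are considered here, and "the series" means these few. Any claim that something is new, unique, unknown or untested is made for them only; others in the source may bear on it.

Compound 1 `COc1ccc(-c2cc(C(=O)/C=C/c3cc(OC)c(OC)c(OC)c3)ccc2N)cc1OC`, in an assay on A549 cells for inhibition of transcription factor p65 (Homo sapiens), read by fluorescence, with a stated time of 2 h; a higher number here means a weaker inhibitor, a lower number a stronger inhibitor: 5440 nM
Compound 2 `COc1ccc(-c2cc(C(=O)/C=C/c3cccc(OC)c3OC)ccc2N)cc1OC`, in this assay: 11900 nM

Of these two numbers compound 1 gives the lower one; compound 2 gives a higher number, and the gap between the two lies beyond the scatter. Compound 3 `COc1cc(/C=C/C(=O)c2ccc(N)c(-c3ccc(F)cc3)c2)cc(OC)c1OC` differs from compound 1 by 4-fluorophenyl in place of 3,4-dimethoxyphenyl on an aromatic carbon. No measured pair covers a change of this kind, so there is no shown step to lean on. The step of a 1.4-fold higher number from compound 1 to compound 3 (0.14 log units; within the scatter) is expected to be modest, a slight move toward a higher number that need not clear the scatter. Compound 3 is therefore estimated at 7500 nM, with a range from 2500 nM to 22000 nM.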

Compound 3, half-maximal inhibitory concentration: 11600 nM
Beside the measured number, compound 3's estimate is 1.5-fold (0.19 log units) below it, and the stated range covers the measured number.
By their numbers in this assay, from the lowest: compound 1; then compounds 3 and 2 (each within the scatter of the next).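

In this assay, going by these compounds alone, the first step at this position, on an aromatic carbon ortho to an amino group, replaces 3,4-dimethoxyphenyl with 4-fluorophenyl and gives a modest weakening (a 2.1-fold higher number from compound 1 to compound 3 (0.33 log units; beyond the scatter)). The position therefore responds to a change of its aryl group, though only slightly beyond the scatter. No available evidence explains this shift. Because this single step removes both methoxy groups and adds fluorine, the contribution of each part remains unresolved. From the compounds shown here alone, how unsubstituted phenyl, 4-methoxyphenyl or a 4-carboxylic acid phenyl would read at this position also remains open.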